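Shortening the chain on the aromatic nitrogen: butyl to propyl

The source may hold more compounds than are shown below. What is called first, only, known or untested is meant among the compounds shown, and "the series" means these compounds.

Compound 1 `CCn1ncnc1-c1ccccc1NCC1=NCCN1` and compound 2 `CCCCn1ncnc1-c1ccccc1NCC1=NCCN1` share one core and differ only in the chain on the aromatic nitrogen. Going by the values given here, in a functional assay with Alpha-1A adrenergic receptor (Homo sapiens) as the target, read by calcium flux (a higher number here means a larger maximal response, a lower number a smaller maximal response), compound 1 gives 107%, while in this assay compound 2 gives 86%, the lowest of the two numbers so far. The step of a number 21 percentage points lower from compound 1 to compound 2 (beyond the scatter) is beyond the scatter but modest. Compound 3 `CCCn1ncnc1-c1ccccc1NCC1=NCCN1` is not yet measured; the change is hydrogen in place of methyl on a saturated chain carbon, three bonds along the chain from an aromatic nitrogen, which read one bond further out is butyl to propyl. Among the compounds with values here, only the step from compound 1 to compound 2 bears on it, running the other way over two chain carbons, so removing one carbon is expected to give back part of that change, because a number 21 percentage points lower from compound 1 to compound 2 (beyond the scatter) was itself modest. For compound 3 in this assay the expected step is a number 10 percentage points higher from compound 2 to compound 3 (within the scatter), near the edge of the scatter. Compound 3 is thus estimated at 96%, between 82% and 110%.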

Compound 3, largest response reached (reported as maximal response), in percent of the reference or control that the assay uses: 96%
Beside the measured number, compound 3's estimate shows no gap at the digits printed; low and high end bracket the measured number.
By their numbers in this assay, from the lowest: compounds 2 and 3 (each within the scatter of the next); then compound 1.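

In this assay, the propyl chain gives a number 10 percentage points higher from compound 2 to compound 3 (within the scatter) and also a number 11 percentage points lower from compound 1 to compound 3 (beyond the scatter), so propyl and butyl are not told apart at this position, while ethyl stands apart from propyl. The earlier pair showed only a difference between ethyl and butyl; here, of the two single-carbon changes on this chain, only methyl in place of hydrogen, two bonds along the chain from an aromatic nitrogen, lies beyond the scatter. No measurement on hand bears on why the maximal response follows the chain in this way.

Going by these compounds, whether a methyl group on the aromatic nitrogen or a longer chain such as pentyl would depart from these numbers stays open. Also open, on these data alone, is how a branched isopropyl chain, or a propyl chain ending in a hydroxyl group or an amine, would read in this assay.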